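Tail amine swap on the quinoline ether series

This account rests on a few compounds, and the source may have more. Where it says the series, first, only, none or still open, it means among the compounds named here.

Three compounds of the series carry a measured number in a functional assay on A549 cells (Homo sapiens) for inhibition, read by MTT assay, with a stated time of 72 h; on this read-out lower numbers stand for stronger inhibition and higher numbers for weaker inhibition. Compound 1 `COc1cc2c(Oc3ccc(NC(=O)c4nn(-c5ccccc5)c(=O)cc4C)cc3F)ccnc2cc1OCCCN1CCN(C)CC1` gives 350 nM; compound 2 `COc1cc2c(Oc3ccc(NC(=O)c4nn(-c5ccccc5C(F)(F)F)c(=O)cc4C)cc3F)ccnc2cc1OCCCN1CCN(C)CC1` gives 170 nM; compound 3 `COc1cc2c(Oc3ccc(NC(=O)c4nn(-c5ccc(Cl)cc5)c(=O)cc4C)cc3F)ccnc2cc1OCCCN1CCCC1` gives 230 nM, the second highest of the three, with both others within the scatter of it. Going by the values given here, the one single-site step seen so far, a 2.1-fold lower number from compound 1 to compound 2 (0.31 log units; beyond the scatter), concerns the aryl substituent, not the chain amine. Compound 4 `COc1cc2c(Oc3ccc(NC(=O)c4nn(-c5ccc(Cl)cc5)c(=O)cc4C)cc3F)ccnc2cc1OCCCN1CCN(C)CC1` differs from compound 3 by 4-methylpiperazin-1-yl in place of pyrrolidin-1-yl on a saturated chain carbon, three bonds along the chain from an oxygen on an aromatic ring. Among the compounds with values here, no measured pair speaks to this change, so no step beyond the scatter is expected: the step from compound 3 to compound 4 is estimated at no change at the digits printed from compound 3 to compound 4 (within the scatter). Compound 4 is therefore expected near 230 nM, with a range of 110 nM to 460 nM in this assay.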

Compound 4, half-maximal inhibitory concentration: 270 nM
Compound 4: the middle estimate sits 1.2-fold (0.07 log units) below what was measured; the range from low to high includes it.
By their numbers in this assay, from the lowest: compounds 2, 3, 4 and 1 (each within the scatter of the next, the first and the last beyond it).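

On a saturated chain carbon, 4-methylpiperazin-1-yl in place of pyrrolidin-1-yl gives a 1.2-fold higher number from compound 3 to compound 4 (0.07 log units; within the scatter) with 4-chlorophenyl held fixed, so this first reading of the chain amine stays within the scatter. Chloro in place of hydrogen on an aromatic carbon gives a 1.3-fold lower number from compound 1 to compound 4 (0.11 log units; within the scatter) and 4-chlorophenyl in place of 2-(trifluoromethyl)phenyl on an aromatic nitrogen gives a 1.6-fold higher number from compound 2 to compound 4 (0.20 log units; within the scatter) and both also stay within the scatter. No supporting data bear on these steps.

On these data alone, whether the amine step holds with other aryl groups remains open. So does the reading of morpholin-4-yl or dimethylamino in the same place.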